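Sulfur to oxygen exchange at compound 3

The compounds below may be only part of what the source reports. "The series", "measured", "known", "first", "only" and "open" are said of these compounds alone.

Measured in a functional assay on T98G cells (Homo sapiens) for inhibition, read by MTT assay, with a stated time of 72 h; on this read-out lower numbers stand for stronger inhibition and higher numbers for weaker inhibition:
- compound 1 `CC1(C)CC(NC(=O)Nc2ccccc2Cl)c2cc(Cl)ccc2O1`: 20000 nM
- compound 2 `CC1(C)CC(NC(=O)NCc2ccccc2)c2cc(Cl)ccc2O1`: 15000 nM
- compound 3 `CC(C)NC(=S)NC1CC(C)(C)Oc2ccc(Cl)cc21`: 91000 nM

In this assay compound 3 gives 91000 nM, the highest of the three numbers and beyond the scatter from both others. Compound 4 `CC(C)NC(=O)NC1CC(C)(C)Oc2ccc(Cl)cc21` is not yet measured. The structural change from compound 3 is a group of 6 heavy atoms (4 carbon, 1 nitrogen, 1 oxygen; no ring) in place of a group of 6 heavy atoms (4 carbon, 1 nitrogen, 1 sulfur; no ring), on an amine nitrogen. Among the measured compounds shown here, the only measured step, a 1.3-fold lower number from compound 1 to compound 2 (0.12 log units; within the scatter), lies within the scatter and sits at another place, so it gives no direct size for this exchange. For the measured compounds named here, no measured pair swaps sulfur for oxygen. The nearest indirect evidence is that compound 1 at 20000 nM and compound 2 at 15000 nM both carry a carbonyl on that amine nitrogen, though with different groups from compound 4. A moderate move towards these numbers is therefore expected, with wide uncertainty. The expected size is a 2.6-fold lower number from compound 3 to compound 4 (0.41 log units; beyond the scatter), which is an estimate only. For compound 4 the estimated value is 35000 nM, with an expected range of 14000 nM to 90000 nM.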

Compound 4, half-maximal inhibitory concentration: > 100000 nM
Compound 4 ended at the assay's limit; the forecaster's own chance of this, stated with the estimate: 10%; middle value at least 2.8-fold (0.45 log units) from the limit.
By their numbers in this assay, from the lowest: compounds 2 and 1 (each within the scatter of the next); then compound 3. At a limit, above all of these: compound 4.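

In this assay compound 4 gives > 100000 nM, which is a limit of the assay and not a number. Oxygen in place of sulfur on the amine nitrogen does not lower the number, but its size has only a floor, an at least 1.0-fold higher number from compound 3 to compound 4 (0.04 log units; that floor lies within the scatter), and stays unresolved because the reading ends at the limit: the limit of > 100000 nM in this assay, at which 1 of the 4 values shown sits. With the carbonyl kept, the group on the amide-type nitrogen now shows an effect that compounds 1 and 2 alone could not show: isopropyl in place of benzyl gives an at least 6.6-fold higher number from compound 2 to compound 4 (0.82 log units; beyond the scatter), and isopropyl in place of 2-chlorophenyl gives an at least 5.0-fold higher number from compound 1 to compound 4 (0.69 log units; beyond the scatter).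

As far as these compounds go, whether a longer chain or a cyclohexyl group on that nitrogen would read closer to compound 2 or to compound 4 remains open. Also open, from the compounds shown here alone, is whether the exchange of sulfur for oxygen would have a measurable size with benzyl on that nitrogen.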